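Moving a naphthyl attachment point on a shared core

The compounds below may be only part of what the source reports. "The series", "measured", "known", "first", "only" and "open" are said of these compounds alone.

The account starts from compound 1 `N#CC1=C(N)OC(c2c[nH]c3ccccc23)=C(C#N)C1c1ccc2ccccc2c1`. In a functional assay, tested at 400 ug/mL (on this read-out higher numbers stand for a stronger effect at the one concentration tested and lower numbers for a weaker effect), compound 1 gives "not active" (no number reported), so it stands with no single number against its two measured relatives: compound 2 `CN(C)c1ccc(C2C(C#N)=C(N)OC(c3c[nH]c4ccccc34)=C2C#N)cc1` gives 26.7% and compound 3 `COc1ccc(C2C(C#N)=C(N)OC(c3c[nH]c4ccccc34)=C2C#N)cc1` gives 28.7%. Going by the values given here, the one measured step, a number 2 percentage points higher from compound 2 to compound 3 (within the scatter), concerns another place and was a number 2 percentage points higher from compound 2 to compound 3 (within the scatter) in size, so it offers no guide to the change at hand. Compound 4 `N#CC1=C(N)OC(c2c[nH]c3ccccc23)=C(C#N)C1c1cccc2ccccc12` differs from compound 1 by naphthalen-1-yl in place of naphthalen-2-yl on a saturated ring carbon. Among the compounds with values here, with compound 1 inactive and no step of the same kind on record, compound 4 is expected to give a weak read-out, estimated at 12%, in the range 0% to 35%.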

Compound 4, a percentage reported as activity, at one concentration (the size of the read-out at that concentration, not a potency): 10.4%
Compound 4: the middle estimate sits 1.6 percentage points above what was measured, and the stated range covers the measured number.
By their numbers in this assay, from the lowest: compound 4; then compounds 2 and 3 (each within the scatter of the next).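

In this assay compound 1 gives "not active" (no number reported) and compound 4 gives 10.4% so naphthalen-1-yl on this saturated ring carbon returns a number, though the step between the two cannot be read. Against the substituted phenyl relatives the read-out is lower, with a number 18.3 percentage points lower from compound 3 to compound 4 (beyond the scatter) and a number 16.3 percentage points lower from compound 2 to compound 4 (beyond the scatter) on the same shared core. Nothing on record gives a cause for these steps. Still open, from the compounds shown here alone, is whether an amine or a carboxylic acid on the naphthalen-1-yl group would keep or raise the read-out at this carbon.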